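This account rests on a few compounds, and the source may have more. Where it says the series, first, only, none or still open, it means among the compounds named here.

Three compounds built on the core of compound 1 `O=C(Nc1ccccc1)c1ccc([N+](=O)[O-])o1` have been measured in an ADME assay on Vero cells (Chlorocebus sabaeus) for cytotoxicity, read by MTT assay, with a stated time of 48 h; a lower number here means that less compound is tolerated, a higher number that more compound is tolerated. Compound 1 gives 6700 nM in this assay, and compound 3 `O=C(NC(=O)c1ccc([N+](=O)[O-])o1)c1ccccc1` gives 3000 nM. For compound 2 `CC(C)(NC(=O)c1ccc([N+](=O)[O-])o1)c1ccccc1` only a limit was recorded in this assay, > 180000 nM, which is the limit of > 180000 nM in this assay, at which 1 of the 3 values shown sits. Compound 2 therefore stands at a limit rather than at a number. Compound 4 `CN(C)c1ccc(C(C)(C)NC(=O)c2ccc([N+](=O)[O-])o2)cc1` differs from compound 2 by dimethylamino in place of hydrogen on an aromatic carbon. Going by the values given here, no step between measured compounds is available to guide this change. The step of an at least 1.2-fold lower number from compound 2 to compound 4 (0.07 log units; that floor lies within the scatter) is expected to be small, none beyond the scatter. Compound 4 is estimated at 150000 nM, within 50000 nM to 300000 nM.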

Compound 4, half-maximal cytotoxic concentration: 79000 nM
The estimate for compound 4 lay 1.9-fold (0.28 log units) above the measured number; the measured number falls inside the stated range.
By their numbers in this assay, from the lowest: compound 3; then compound 1; then compound 4. At a limit, above all of these: compound 2.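

Dimethylamino in place of hydrogen on an aromatic carbon, para to a large group, gives in this assay an at least 2.2-fold lower number from compound 2 to compound 4 (0.35 log units; beyond the scatter). Going by these compounds alone, the earlier compounds offered no step at all, so this is the first sign that a change at this position can move the number beyond the scatter. The size of the step is only a floor, because compound 2 stands at a limit and not at a number: the limit of > 180000 nM in this assay, at which 1 of the 4 values shown sits.

As far as these compounds go, whether the step depends on dimethylamino itself stays open. A primary amine, a methoxy group or a carboxylic acid on the same aromatic carbon could each give a different answer.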